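Nitro series: from compound 2 to compound 3

The compounds below may be only part of what the source reports. "The series", "measured", "known", "first", "only" and "open" are said of these compounds alone.

Measured in an ADME assay on J774.A1 cells (Mus musculus) for cytotoxicity, read by MTT assay, with a stated time of 48 h; a lower number here means that less compound is tolerated, a higher number that more compound is tolerated:
- compound 1 `COC(=O)c1c([N+](=O)[O-])noc1-c1cccc(-c2cnco2)c1`: 19700 nM
- compound 2 `O=C(NCc1ccc(F)cc1)c1c([N+](=O)[O-])noc1-c1ccc([N+](=O)[O-])cc1`: "not determined" (no result reported)

Compound 2 has no number to work from. Its entry in this assay reads "not determined" (no result reported), so it gives no starting point on the scale and no rank relative to compound 1. For the measured compounds named here, the only number is the one for compound 1, at 19700 nM.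

Compound 3 `CC(C)CCNC(=O)c1c([N+](=O)[O-])noc1-c1ccc([N+](=O)[O-])cc1` is the next compound to be read. The structural change is isobutyl in place of 4-fluorophenyl on a saturated chain carbon bound to an amide-type nitrogen. Put another way, 4-fluorobenzyl gives way to isopentyl, or (4-fluorobenzyl)amino to isopentylamino.

Going by the values given here, the series contains no measured pair differing in one place, so the size of this change cannot be read from the data. With compound 2 unmeasured, no direction can be assigned either. The working expectation in this assay is therefore no shift beyond the usual scatter, with compound 1 at 19700 nM as the sole reference, and the range is kept wide.

For compound 3 the expected value is 20000 nM, with an estimated range of 6000 nM to 70000 nM.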

Compound 3, half-maximal cytotoxic concentration: 67000 nM
Compound 3: the middle estimate sits 3.4-fold (0.53 log units) below what was measured, within the range that was stated.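

No new step can be read from compound 3: compound 2 has no value to pair with it in this assay and compound 1 differs from it in more than one place. On these data alone, how 4-fluorobenzyl to isopentyl shifts the tolerated concentration stays open. No evidence on hand bears on this result.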